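This account rests on a few compounds, and the source may have more. Where it says the series, first, only, none or still open, it means among the compounds named here.

Measured in an ADME assay on HepG2 cells (Homo sapiens) for cytotoxicity, read by luminescence, CellTiter-Glo and ATP content, with a stated time of 72 h; on this read-out higher numbers stand for an effect only at larger amounts of compound and lower numbers for an effect already at smaller amounts:
- compound 1 `COc1ccccc1Oc1ccc2c(NCCCNCc3ccco3)ccnc2c1`: 6500 nM
- compound 2 `N#Cc1ccc(Cc2ccc3c(NCCCNCc4ccco4)ccnc3c2)cc1`: 7910 nM

Compound 2 holds the higher of the two numbers in this assay, with compound 1 the nearest; the step of a 1.2-fold higher number from compound 1 to compound 2 (0.09 log units; within the scatter) lies within the scatter, so the two cannot be told apart on this read-out.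

Compound 3 `c1coc(CNCCCNc2ccnc3cc(-c4cccc5ccccc45)ccc23)c1` arises from compound 2 through a single change: naphthalen-1-yl in place of 4-cyanobenzyl on an aromatic carbon. For the measured compounds named here, the only measured step that bears on this is the one from compound 1 to compound 2, which also exchanged the group on that same aromatic carbon of the shared core, and it gave a 1.2-fold higher number from compound 1 to compound 2 (0.09 log units; within the scatter). With one within-scatter precedent for a swap at this position, no step beyond the scatter is expected for compound 3 in this assay, though a single precedent leaves the direction open.

Compound 3 is therefore estimated at 7000 nM in this assay, within a range of 2500 nM to 20000 nM, which amounts to an expected step of a 1.1-fold lower number from compound 2 to compound 3 (0.05 log units; within the scatter).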

Compound 3, half-maximal effective concentration: 5600 nM
Compound 3: the middle estimate sits 1.3-fold (0.10 log units) above what was measured; the measured number falls inside the stated range.
By their numbers in this assay, from the lowest: compounds 3, 1 and 2 (each within the scatter of the next).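

In this assay, a third kind of group on this aromatic carbon still gives no step beyond the scatter: swapping 4-cyanobenzyl for naphthalen-1-yl gives a 1.4-fold lower number from compound 2 to compound 3 (0.15 log units; within the scatter), and swapping 2-methoxyphenoxy for it gives a 1.2-fold lower number from compound 1 to compound 3 (0.06 log units; within the scatter). The earlier pair showed only groups that each carry one six-membered aromatic ring of carbon only, set off from the shared core by a linking atom, whereas naphthalen-1-yl brings two such rings, sits directly on the core and, unlike 4-cyanobenzyl, has no hydrogen-bond acceptor and no triple bond, so these differences together leave the read-out indistinguishable across the three compounds. Nothing at hand offers a reason why the read-out stays the same across these swaps.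

On these data alone, all three groups at this position are uncharged and built around aromatic rings, so it remains open whether an amine or a carboxylic acid on this carbon would produce a step beyond the scatter. The chain on the shared core is the same in all three compounds, which leaves open what a longer chain would do in this assay.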